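Working notes on the shared core: compound 3 to compound 4

This account rests on a few compounds, and the source may have more. Where it says the series, first, only, none or still open, it means among the compounds named here.

The series rests on one core, seen in compound 1 `Cc1ccc(NC(=O)C(Cl)Cl)cc1`, compound 2 `O=C(Nc1ccc(Br)cc1)C(Cl)Cl` and compound 3 `COc1ccc(NC(=O)C(Cl)Cl)cc1`. In a functional assay on Bel-7402 cells (Homo sapiens) for antiproliferative activity, read by MTT assay, with a stated time of 72 h (a lower number here means a stronger inhibitor, a higher number a weaker inhibitor), compound 2 gives 9770 nM and compound 3 gives 192000 nM, while compound 1 has no result, "not determined" (no result reported). Within the data shown here, compound 3 thus holds the highest of the two numbers, with compound 2 as its nearest neighbour, and the single step between them, a 20-fold higher number from compound 2 to compound 3 (1.29 log units; beyond the scatter), is large and beyond the scatter.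

Compound 4 `O=C(Nc1ccc(SC(F)(F)F)cc1)C(Cl)Cl` carries the change ((trifluoromethyl)sulfanyl in place of methoxy on an aromatic carbon). Among the measured compounds shown here, only one measured step bears on it: the exchange of bromo for methoxy at this place moved the number by a large margin, and the present exchange removes that same methoxy again in favour of another non-methoxy group. The step of a 16-fold lower number from compound 3 to compound 4 (1.20 log units; beyond the scatter) is therefore expected to be large and downward, since compound 2 with bromo at that place gives 9770 nM. Compound 4 is estimated at 12000 nM, with a range from 3000 nM to 60000 nM.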

Compound 4, half-maximal inhibitory concentration: 3610 nM
Estimate against measurement, compound 4: 3.3-fold (0.52 log units) above, and the stated range covers the measured number.
By their numbers in this assay, from the lowest: compound 4; then compound 2; then compound 3.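

In this assay, (trifluoromethyl)sulfanyl in place of methoxy on the aromatic carbon gives a 53-fold lower number from compound 3 to compound 4 (1.73 log units; beyond the scatter) and so methoxy, with the highest number, now stands against two other groups at this place rather than bromo alone. The exchange of bromo for the same group gives a 2.7-fold lower number from compound 2 to compound 4 (0.43 log units; beyond the scatter) and this modest step, still beyond the scatter, shows that the position also separates the two groups that lie well under methoxy, with compound 4 holding the lowest number of the three. Nothing among the data shown accounts for this order.

Compound 1 has no number and so cannot be placed in this order. Going by these compounds, whether an amine, a carboxylic acid or a longer alkyl chain at this place would fall nearer compound 4 or compound 3 remains open.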